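Bromo for Fluoro: Compound 3 to Compound 4

The source may report more compounds than this note shows. Statements on the series, on what has been measured and on what is new or still open speak of the compounds shown alone.

Measured in a functional assay on the whole organism for inhibition, with Lemna aequinoctialis as the target, tested at 1000 ug/mL; a lower number here means less inhibition of growth, a higher number more inhibition of growth at the concentration tested:
Compound 1, `Cc1cccc(NC(=S)N/N=C2\C(=O)Nc3ccc([N+](=O)[O-])cc32)c1`, gives 25%.
Compound 2, `Cc1ccc(NC(=S)N/N=C2\C(=O)Nc3ccc([N+](=O)[O-])cc32)cc1`, gives 30%.
Compound 3, `O=C1Nc2ccc([N+](=O)[O-])cc2/C1=N/NC(=S)Nc1ccc(F)cc1`, gives 20%.

Compound 3 shows the lowest of the three numbers, but the gaps are small: a number 5 percentage points lower from compound 1 to compound 3 (within the scatter) and a number 10 percentage points lower from compound 2 to compound 3 (within the scatter), both within the scatter. Compound 4, `O=C1Nc2ccc([N+](=O)[O-])cc2/C1=N/NC(=S)Nc1ccc(Br)cc1`, differs from compound 3 by bromo in place of fluoro on an aromatic carbon. Going by the values given here, no measured step exchanges one halogen for another; the only step touching the same aromatic carbon is a number 10 percentage points lower from compound 2 to compound 3 (within the scatter), and the other ring changes, a number 5 percentage points higher from compound 1 to compound 2 (within the scatter) and a number 5 percentage points lower from compound 1 to compound 3 (within the scatter), were likewise within the scatter. Compound 4 is therefore expected to show no step beyond the scatter, a number 5 percentage points higher from compound 3 to compound 4 (within the scatter). Compound 4 is estimated at 25%, with a range from 10% to 45%.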

Compound 4, percent growth inhibition at one concentration: 20%
For compound 4 the middle estimate is 5 percentage points above the measured one, within the range that was stated.
By their numbers in this assay, from the lowest: compounds 3, 4, 1 and 2 (each within the scatter of the next).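

In this assay, going by these compounds alone, the first exchange of one halogen for another at this aromatic carbon gives no change at the digits printed from compound 3 to compound 4 (within the scatter) so fluoro and bromo cannot be told apart here. Bromo in place of methyl gives a number 10 percentage points lower from compound 2 to compound 4 (within the scatter) and 4-bromophenyl in place of 3-methylphenyl gives a number 5 percentage points lower from compound 1 to compound 4 (within the scatter) so bromo, like fluoro, leaves the number within the scatter of the methyl compounds. No other measurement shown bears on this result. From the compounds shown here alone, whether an amine, a carboxylic acid or a longer chain at this place would move the number beyond the scatter stays open.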